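Cyano-substituted series: from phenylsulfanyl to (3-nitrophenyl)amino

The source may hold more compounds than are shown below. What is called first, only, known or untested is meant among the compounds shown, and "the series" means these compounds.

Measured so far in a functional assay (aorta) with Rattus norvegicus as the target; a higher number here means a weaker inhibitor, a lower number a stronger inhibitor:
- compound 1 (`CC1(C)Oc2ccc(C#N)cc2[C@@H](/N=C(\NC#N)Sc2ccccc2)[C@@H]1O`): 4900 nM
- compound 2 (`CC1(C)Oc2ccc(C#N)cc2[C@@H](NC(=O)Nc2ccncc2)[C@@H]1O`): 8500 nM

On these two numbers, compound 1 stands within the scatter of compound 2, and the pair cannot be separated in this assay on potency. The next compound to be read is compound 3 (`CC1(C)Oc2ccc(C#N)cc2[C@@H](/N=C(\NC#N)Nc2cccc([N+](=O)[O-])c2)[C@@H]1O`), which is not yet measured. Relative to compound 1, it carries (3-nitrophenyl)amino in place of phenylsulfanyl on a carbon with a double bond to nitrogen. Going by the values given here, no measured pair covers this exchange, so the expectation has little to rest on and its range is kept wide. Starting from compound 1 at 4900 nM as the only anchor with the same leaving group, a modest move toward a lower number in this assay is expected, though not one beyond the scatter. The estimated step is a 1.6-fold lower number from compound 1 to compound 3 (0.21 log units; within the scatter) in that direction. Compound 3 is estimated at 3000 nM, with an expected range from 600 nM to 13000 nM.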

Compound 3, half-maximal inhibitory concentration: 670 nM
Compound 3: the middle estimate sits 4.5-fold (0.65 log units) above what was measured; low and high end bracket the measured number.
By their numbers in this assay, from the lowest: compound 3; then compounds 1 and 2 (each within the scatter of the next).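

In this assay, the exchange on the carbon with a double bond to nitrogen gives a 7.3-fold lower number from compound 1 to compound 3 (0.86 log units; beyond the scatter). Going by these compounds alone, this is the first step that lies beyond the scatter, and it shows that the group at this place can shift the reading while the core of compound 1 stays the same. Both groups carry one six-membered aromatic ring of carbon only, so the step goes with the replacement of the sulfur link by an amino link, the addition of the nitro group, or the two together, and this single pair cannot separate them. No measured evidence is available on what lies behind this step.

Still open, from the compounds shown here alone, is whether phenylamino, with an amino link but no nitro group, would read close to compound 3 or stay close to compound 1, which would assign the step to one part of the change. Also open, going by these compounds, is whether the ring itself is needed at this place, which a saturated group such as cyclohexylamino or a short chain such as ethylamino would test.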